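Amide-to-urea series at the adenosine receptor: benzyl urea

The source may hold more compounds than are shown below. What is called first, only, known or untested is meant among the compounds shown, and "the series" means these compounds.

Measured so far:
- compound 1, `COc1ccc(C(=O)Nc2nn(-c3ccccc3)c(=O)c3ccccc23)cc1`: 0%
- compound 2, `COc1ccc(OC)c(NC(=O)Nc2nn(-c3ccccc3)c(=O)c3ccccc23)c1`: 0%
- compound 3, `COc1ccccc1NC(=O)Nc1nn(-c2ccccc2)c(=O)c2ccccc12`: 0%

In an assay on CHO cells for displacement of a labelled ligand from adenosine receptor A1 (Homo sapiens), tested at 10 uM (a lower number here means less inhibition, a higher number more inhibition at the concentration tested (going by the name of the read-out)), compound 1 gives 0%, compound 2 gives 0% and compound 3 gives 0%. Compound 3 stands level with compounds 1 and 2 at the digits shown. The two steps into it read no change at the digits printed from compound 1 to compound 3 (within the scatter) and no change at the digits printed from compound 2 to compound 3 (within the scatter), so neither the change from an amide to a urea nor the removal of a methoxy group has moved this assay out of the scatter.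

Compound 4, `O=C(NCc1ccccc1)Nc1nn(-c2ccccc2)c(=O)c2ccccc12`, is the next entry. It differs from compound 3 as follows: benzyl in place of 2-methoxyphenyl on an amide-type nitrogen. The step from compound 1 to compound 3 is the one that bears most on it, since it also alters the group on the carbonyl side of the shared core; its size was within the scatter, and the step from compound 2 to compound 3 was likewise flat. Among the compounds with values here, nothing among the measured compounds suggests that the benzylamino group should behave differently, though no benzyl analogue has been tested.

The step of no change at the digits printed from compound 3 to compound 4 (within the scatter) is therefore expected to be none beyond the scatter. Compound 4 is estimated at 0%, with a range of -5% to 10%.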

Compound 4, a percentage reported as inhibition, at one concentration (the size of the read-out at that concentration, not a potency): 20%
For compound 4 the middle estimate is 20 percentage points below the measured one, outside the stated range (above it).
By their numbers in this assay, from the lowest: compounds 1, 2 and 3 (each within the scatter of the next); then compound 4.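

Within the data shown here, in (this assay), the amide-type nitrogen of the urea is the first place where a change moves the read-out: benzyl in place of 2-methoxyphenyl gives a step beyond the scatter (a number 20 percentage points higher from compound 3 to compound 4 (beyond the scatter)). The result holds against both other compounds, with benzyl in place of 2,5-dimethoxyphenyl (a number 20 percentage points higher from compound 2 to compound 4 (beyond the scatter)) and with benzylamino in place of 4-methoxyphenyl on a carbonyl carbon (a number 20 percentage points higher from compound 1 to compound 4 (beyond the scatter)), so the three methoxyphenyl compounds stand level and compound 4 stands apart. No measurement at hand accounts for this step.

Open, going by these compounds, is whether a 2-phenylethyl group, a longer chain, or a cyclohexylmethyl group on the same nitrogen would carry the read-out further. Also open, on these data alone, is whether a methoxy group on the benzyl ring would keep the step.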